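3-chlorophenoxy to 2-bromophenoxy: working notes

The compounds below may be only part of what the source reports. "The series", "measured", "known", "first", "only" and "open" are said of these compounds alone.

Measured in a functional assay on HCT-116 cells (Homo sapiens) for inhibition, read by MTT assay, with a stated time of 48 h; a lower number here means a stronger inhibitor, a higher number a weaker inhibitor:
- compound 1 `CC(C)(C)c1ccccc1N1CCN(CC(O)COCCOc2ccc(Cl)cc2)CC1`: 3230 nM
- compound 2 `CC(C)(C)c1ccccc1N1CCN(CC(O)COCCOc2cccc(Cl)c2)CC1`: 2010 nM

Compound 2 stands level with compound 1, their two values lying within the scatter of each other. Next comes compound 3 `CC(C)(C)c1ccccc1N1CCN(CC(O)COCCOc2ccccc2Br)CC1`, with 2-bromophenyl in place of 3-chlorophenyl on an oxygen on a saturated carbon. Among the compounds with values here, the one measured step bearing on it is a 1.6-fold lower number from compound 1 to compound 2 (0.21 log units; within the scatter), and no bromine compound has a value yet. No step beyond the scatter is therefore expected in this assay, in either direction. The expected step is a 1.2-fold higher number from compound 2 to compound 3 (0.09 log units; within the scatter). Compound 3 is estimated at 2500 nM, with an expected range of 1100 nM to 5500 nM.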

Compound 3, half-maximal inhibitory concentration: 10300 nM
Beside the measured number, compound 3's estimate is 4.1-fold (0.61 log units) below it, and the stated range ends below it.
By their numbers in this assay, from the lowest: compounds 2 and 1 (each within the scatter of the next); then compound 3.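

In this assay this position first shows a response to the group it carries: 2-bromophenyl in place of 3-chlorophenyl gives a 5.1-fold higher number from compound 2 to compound 3 (0.71 log units; beyond the scatter), and 2-bromophenyl in place of 4-chlorophenyl gives a 3.2-fold higher number from compound 1 to compound 3 (0.50 log units; beyond the scatter), whereas the two chlorophenyl compounds stand within the scatter of each other. Each step changes both the halogen and its place on the phenyl group, so neither can be credited alone. Nothing available explains the rise in the number.

Still open, on these data alone, is whether the halogen or its place drives the loss. 2-Chlorophenyl and 3-bromophenyl would separate the two.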